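Swapping the Halogenated Aryl for Dimethylphenyl: Permeability Outlook

The source may hold more compounds than are shown below. What is called first, only, known or untested is meant among the compounds shown, and "the series" means these compounds.

Three close relatives share one core. Compound 1 `Cc1oc(-c2c(Cl)cccc2Br)nc1CN1CCC(C(=O)NCCCN2C[C@H](C)C[C@H](C)C2)CC1` carries a 2-bromo-6-chlorophenyl group on the five-membered ring, and in a physicochemical assay for permeability, using PAMPA (a lower number here means that the compound crosses the layer more slowly, a higher number that the compound crosses the layer faster), compound 1 gives "not determined" (no result reported). Its relatives set the scene: compound 2 `Cc1ccccc1-c1nc(CN2CCC(C(=O)NCCCCN3C[C@H](C)C[C@H](C)C3)CC2)c(C)o1` gives 288 10^-6 cm/s in this assay, and compound 3 `Cc1cccc(Cl)c1-c1nc(CN2CCC(C(=O)NCCCN3CCCC(C)C3)CC2)c(C)o1` gives 651 10^-6 cm/s there. Compound 4 `Cc1cc(C)cc(-c2nc(CN3CCC(C(=O)NCCCN4C[C@H](C)C[C@H](C)C4)CC3)c(C)o2)c1` is compound 1 with a single change: 3,5-dimethylphenyl in place of 2-bromo-6-chlorophenyl on an aromatic carbon. Among the measured compounds shown here, no step from compound 1 to another measured compound is recorded, so the expectation for compound 4 in this assay rests on compounds 2 and 3 alone; a shift of this kind is expected to be small, not clearly beyond the scatter. Compound 4 is therefore estimated at 400 10^-6 cm/s, with a likely range from 150 10^-6 cm/s to 900 10^-6 cm/s.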

Compound 4, apparent permeability: 864 10^-6 cm/s
Estimate against measurement, compound 4: 2.2-fold (0.33 log units) below; the range from low to high includes it.
By their numbers in this assay, from the lowest: compound 2; then compounds 3 and 4 (each within the scatter of the next).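

Among the compounds shown here, no step from compound 1 to compound 4 can be read: in this assay compound 1 gives "not determined" (no result reported). From the compounds shown here alone, what replacing 2-bromo-6-chlorophenyl with 3,5-dimethylphenyl does to this read-out stays open. No evidence here explains the value of compound 4.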